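The source may hold more compounds than are shown below. What is called first, only, known or untested is meant among the compounds shown, and "the series" means these compounds.

Measured compounds:
compound 1, `CCN(Cc1ccncc1)C(=S)SCc1ccc(C(=O)Nc2ccccc2N)cc1`, 86.2%
compound 2, `Nc1ccccc1NC(=O)c1ccc(CSC(=S)N2CCN(Cc3ccccc3)CC2)cc1`, 29.3%
compound 3, `Nc1ccccc1NC(=O)c1ccc(CSC(=S)N2CCN(Cc3cccnc3)CC2)cc1`, 89.2%

The three measured compounds share the core of compound 1 and differ only in the group on the thiocarbonyl carbon. In a functional assay on A-375 cells (Homo sapiens) for antiproliferative activity, read by CCK-8 assay, with a stated time of 72 h, tested at 8 uM (a lower number here means a weaker effect, a higher number a stronger effect of the compound at the concentration tested), compound 1 gives 86.2%, the second highest of the three numbers. Compound 3 gives 89.2%, which lies within the scatter of compound 1, so the two cannot be ordered. Compound 2 gives 29.3%, far below both. Within the data shown here, the only one-place step among the measured compounds is a number 59.9 percentage points higher from compound 2 to compound 3 (beyond the scatter): a pyridin-3-yl in place of phenyl went with a very large gain.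

Compound 4, `Nc1ccccc1NC(=O)c1ccc(CSC(=S)N2CCc3ccccc32)cc1`, has not yet been measured in this assay. It differs from compound 1 by 2,3-dihydro-1H-indol-1-yl in place of ethyl((pyridin-4-yl)methyl)amino on a thiocarbonyl carbon. The step from compound 2 to compound 3 bears on this change: there the compound carrying phenyl rather than a six-membered aromatic ring with a hetero atom gave the far lower number. Compound 4 likewise carries no six-membered aromatic ring with a hetero atom in the entering group, and the change here is larger than a single ring swap. A drop beyond the scatter is therefore expected in this assay, though its size is uncertain because only a number 59.9 percentage points higher from compound 2 to compound 3 (beyond the scatter) is available as a guide. Compound 4 is estimated at 45%, with a range from 20% to 75%, so the expected step is a number 41.2 percentage points lower from compound 1 to compound 4 (beyond the scatter).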

Compound 4, a percentage reported as inhibition, at one concentration (the size of the read-out at that concentration, not a potency): 85.4%
Beside the measured number, compound 4's estimate is 40.4 percentage points below it; measured number outside the range, above it.
By their numbers in this assay, from the lowest: compound 2; then compounds 4, 1 and 3 (each within the scatter of the next).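

In this assay, the exchange of ethyl((pyridin-4-yl)methyl)amino for 2,3-dihydro-1H-indol-1-yl on the thiocarbonyl carbon gives a number 0.8 percentage points lower from compound 1 to compound 4 (within the scatter), so this position tolerates a substantial change of group with no visible loss at the concentration tested. The entering group has a six-membered aromatic ring of carbon only and no hydrogen-bond acceptor, so a six-membered aromatic ring with a hetero atom is not needed for a high number here, and compound 4 goes against any general reading of a number 59.9 percentage points higher from compound 2 to compound 3 (beyond the scatter) as a rule for this position. The data shown offer no measured basis for explaining why compound 4 keeps the number of compound 1 while compound 2 does not.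

On these data alone, it remains open whether a diethylamino group, with no ring at all, or a morpholin-4-yl group on the thiocarbonyl carbon would also keep this level. The read-out is taken at one concentration, so it also leaves open whether compound 1, compound 3 and compound 4 would still stand together in full concentration-response measurements.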